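The source may hold more compounds than are shown below. What is called first, only, known or untested is meant among the compounds shown, and "the series" means these compounds.

Compound 3 `CCc1cccc(CNC(=O)c2nc3ccc(F)c(COCc4ccc(C(=O)O)cc4)c3c(=O)[nH]2)c1` is the reference point for this note. In an ADME assay on HEK293 cells (Homo sapiens) for cytotoxicity, read by resazurin assay, with a stated time of 72 h (a higher number here means that more compound is tolerated, a lower number that less compound is tolerated), compound 3 gives > 20000 nM, which is a limit of the assay and not a number. Compound 1 `CCc1cccc(CNC(=O)c2nc3ccc(F)c(OCCc4ccc(C(=O)O)cc4)c3c(=O)[nH]2)c1` also sits at a limit, giving > 20000 nM in this assay. Compound 2 `CCc1cccc(CNC(=O)c2nc3ccc(F)c(COc4ccc(CC(=O)O)cc4)c3c(=O)[nH]2)c1` gives > 20000 nM in this assay, again a limit. The steps among these three are therefore unreadable: a step that the two limits leave unreadable from compound 1 to compound 2, a step that the two limits leave unreadable from compound 1 to compound 3 and a step that the two limits leave unreadable from compound 2 to compound 3. What the series shows is the limit of > 20000 nM in this assay, at which 3 of the 3 values shown sit.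

Compound 4 `CCc1cccc(CNC(=O)c2nc3ccc(Br)c(COCc4ccc(C(=O)O)cc4)c3c(=O)[nH]2)c1` differs from compound 3 in one place: bromo in place of fluoro on an aromatic carbon. Among the compounds with values here, no measured step bears on a change of halogen at this position; the three measured steps concern the side chain, and none of them gives a size. Within the data shown here, the only guidance is that all three measured compounds are tolerated up to the limit. Compound 4 is therefore expected to sit at that same limit, the estimated step being a number no higher from compound 3 to compound 4 (the limit leaves the size open). The estimate for compound 4 is 20000 nM, expected to lie between 10000 nM and 40000 nM.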

Compound 4, half-maximal cytotoxic concentration: > 20000 nM
Compound 4: a limit, no number (the forecaster's own chance of this, stated with the estimate: 85%); the middle value sits exactly at the limit.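

Compound 3 and compound 4 both sit at a limit in this assay, and the step from fluoro to bromo cannot be read. The compounds shown leave open how much of any of them is tolerated past that limit, and whether the halogen or side chain changes this: the limit of > 20000 nM in this assay, at which 4 of the 4 values shown sit.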